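Three Compounds Measured, a Fourth Awaiting Its Number

The source may hold more compounds than are shown below. What is called first, only, known or untested is meant among the compounds shown, and "the series" means these compounds.

Of the compounds shown here, three have so far been tested in a functional assay on DU-145 cells (Homo sapiens) for cytotoxicity, read by trypan blue exclusion, with a stated time of 96 h; a higher number here means a weaker inhibitor, a lower number a stronger inhibitor. Compound 1 `O=S(=O)(/C=C/c1ccc(Br)cc1)Nc1ccc(F)cc1` gives 10000 nM in this assay. Compound 2 `COc1ccc(NS(=O)(=O)/C=C/c2cc(OC)c(OC)c(OC)c2)cc1N` gives 35000 nM in this assay. Compound 3 `COC(=O)C(C)Nc1cc(NS(=O)(=O)/C=C/c2c(OC)cc(OC)cc2OC)ccc1OC` gives 100 nM in this assay, the lowest of the three numbers; its gaps to compound 1 and to compound 2 both lie beyond the scatter, so compound 3 is the strongest inhibitor of the set. Compound 1 and compound 2 each differ from compound 3 in more than one place, so their values serve only to show where compound 3 stands.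

Compound 4 `COc1cc(OC)c(/C=C/S(=O)(=O)Nc2ccc(OC)c(NC(C(=O)O)c3ccc(F)cc3)c2)c(OC)c1` has not yet been measured. It differs from compound 3 in a single place: carboxy(4-fluorophenyl)methyl in place of 1-(methoxycarbonyl)ethyl on a nitrogen on an aromatic ring. Cut one bond further out, the change reads (1-(methoxycarbonyl)ethyl)amino to (carboxy(4-fluorophenyl)methyl)amino; everything else in compound 4 is as in compound 3.

Among the compounds with values here, no measured pair shows this change, so nothing in the data fixes its size or direction. The account expects a modest move toward a weaker inhibitor, with a 3.0-fold higher number from compound 3 to compound 4 (0.48 log units; beyond the scatter) as the expected step. Compound 4 is estimated at 300 nM in this assay, within a range from 50 nM to 2000 nM.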

Compound 4, half-maximal inhibitory concentration: 75 nM
The estimate for compound 4 lay 4.0-fold (0.60 log units) above the measured number, and the stated range covers the measured number.
By their numbers in this assay, from the lowest: compounds 4 and 3 (each within the scatter of the next); then compound 1; then compound 2.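

In this assay, carboxy(4-fluorophenyl)methyl in place of 1-(methoxycarbonyl)ethyl on a nitrogen on an aromatic ring gives a 1.3-fold lower number from compound 3 to compound 4 (0.12 log units; within the scatter), so this assay does not tell the two compounds apart. Within the data shown here, this is the first pair in the set that differs in one place, and it shows that a group of 11 heavy atoms, with a six-membered aromatic ring and a hydrogen-bond donor, can stand on this nitrogen instead of a group of 6 heavy atoms with neither, with no change beyond the scatter. Nothing in the available data explains why the number holds across this exchange.

The step exchanges the methoxycarbonyl for the carboxy group and the methyl for the 4-fluorophenyl ring together, and the compounds shown do not separate these two exchanges. They also leave open how a plain phenyl ring without the fluorine, a primary amide in place of the carboxy group, or a longer chain on this nitrogen would read in this assay.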